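Removing One Trifluoromethyl from the Aniline of Compound 1

This account rests on a few compounds, and the source may have more. Where it says the series, first, only, none or still open, it means among the compounds named here.

Among the measured compounds shown here, compound 1 `CN(c1cccc2c1CN(c1nc(Nc3cc(C(F)(F)F)cc(C(F)(F)F)c3)ncc1C(F)(F)F)C2)S(C)(=O)=O` is the only member of this small set with a numerical result: in a functional assay on U-87MG ATCC cells for antiproliferative activity against U-87 MG (Homo sapiens), read by spectrophotometry, with a stated time of 2 days (a lower number here means a stronger inhibitor of growth, a higher number a weaker inhibitor of growth), compound 1 gives 16800 nM. Compound 2 `COc1cc(Nc2ncc(C(F)(F)F)c(N3Cc4cccc(N(C)S(C)(=O)=O)c4C3)n2)cc(OC)c1` reaches only the limit of the assay, giving > 30000 nM in this assay. Compound 3 `Cc1ccc(Nc2ncc(C(F)(F)F)c(N3Cc4cccc(N(C)S(C)(=O)=O)c4C3)n2)c(Cl)c1` likewise stops at the limit, with > 30000 nM. The step that the two limits leave unreadable from compound 2 to compound 3 is unreadable because both sit at the limit of > 30000 nM in this assay, at which 2 of the 3 values shown sit. Compound 4 `CN(c1cccc2c1CN(c1nc(Nc3cccc(C(F)(F)F)c3)ncc1C(F)(F)F)C2)S(C)(=O)=O` differs from compound 1 by hydrogen in place of trifluoromethyl on an aromatic carbon. For the measured compounds named here, no measured step covers the loss of a single trifluoromethyl; the other changes on that ring, in compound 2 and compound 3, both ended at limits, so a modest weakening is expected. The expected step is a 1.5-fold higher number from compound 1 to compound 4 (0.17 log units; within the scatter). For compound 4 the estimated value in this assay is 25000 nM, with a range from 10000 nM to 60000 nM.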

Compound 4, concentration for 50% growth inhibition: > 30000 nM
Compound 4: only a limit was reported; the forecaster's own chance of this, stated with the estimate: 40%; middle value at least 1.2-fold (0.07 log units) from the limit.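

In this assay, among the compounds shown here, hydrogen in place of trifluoromethyl on an aromatic carbon gives an at least 1.7-fold higher number from compound 1 to compound 4 (0.25 log units; that floor lies within the scatter), the first step on this ring that can be read at all, though only as a floor, since compound 4 stands at a limit. For the compounds shown here, compound 1 thus remains the only compound with a numerical value, and the one trifluoromethyl left in compound 4 does not bring a number within reach. The steps among compound 2, compound 3 and compound 4 cannot be read because all three stand at the same limit: the limit of > 30000 nM in this assay, at which 3 of the 4 values shown sit.

On these data alone, how far compound 4 lies past its limit stays open, so the true size of the step is unknown. Also open, as far as these compounds go, is how an amine or a nitrile on that aromatic carbon would compare with compound 1.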